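This account rests on a few compounds, and the source may have more. Where it says the series, first, only, none or still open, it means among the compounds named here.

Measured so far:
compound 1, `CC(=O)N1CCC(C(=O)N(CCCN2CCN(Cc3ccc(Cl)nc3)CC2)c2ccc(C)c(Cl)c2)CC1`: > 53100 nM
compound 2, `CC(=O)N1CCC(C(=O)N(CCCN2CCN(Cc3cnc(Cl)s3)CC2)c2ccc(C)c(Cl)c2)CC1`: > 52300 nM

In an ADME assay (Homo sapiens) for cytotoxicity (a higher number here means that more compound is tolerated, a lower number that less compound is tolerated), compound 1 reaches only a limit, > 53100 nM. In this assay compound 2 likewise reaches only a limit, > 52300 nM. Compound 2 thus sits at the limit of > 52300 nM in this assay, at which 1 of the 2 values shown sits. Compound 1 sits at the limit of > 53100 nM in this assay, at which 1 of the 2 values shown sits. Compound 3, `CC(=O)N1CCC(C(=O)N(CCCN2CCN(Cc3cccnc3)CC2)c2ccc(C)c(Cl)c2)CC1`, is not yet measured; it differs from compound 2 in this way: pyridin-3-yl in place of 2-chloro-1,3-thiazol-5-yl on a saturated chain carbon bound to an amine nitrogen in a ring. Within the data shown here, the one measured step, a step that the two limits leave unreadable from compound 1 to compound 2, also exchanged the ring on that saturated chain carbon, yet its size cannot be read, so no direction can be expected. Compound 3 is expected to give 55000 nM, between 30000 nM and 100000 nM. That amounts to an expected step that the limit leaves unreadable from compound 2 to compound 3.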

Compound 3, half-maximal cytotoxic concentration: > 56700 nM
Compound 3 ended at the assay's limit; the forecaster's own chance of this, stated with the estimate: 80%; middle value at least 1.0-fold (0.01 log units) away from the limit.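

Among these compounds, compound 1, compound 2 and compound 3 all end at limits in this assay, so no step among them can be read. As far as these compounds go, what stays open is whether exchanging the ring on that saturated chain carbon changes cytotoxicity at all.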